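The source may report more compounds than this note shows. Statements on the series, on what has been measured and on what is new or still open speak of the compounds shown alone.

Measured compounds:

Compound 1, `Cc1nc(-c2cccnc2)sc1-c1nnc(-c2ccccc2Cl)o1`. In an ADME assay on HeLa cells (Homo sapiens) for cytotoxicity, read by MTT assay (a higher number here means that more compound is tolerated, a lower number that less compound is tolerated), compound 1 gives > 100 ug/mL, which is a limit of the assay and not a number.
Compound 2, `COc1ccccc1-c1nnc(-c2sc(-c3cccnc3)nc2C)o1`. In this assay compound 2 gives > 100 ug/mL, again a limit of the assay.
Compound 3, `Cc1nc(-c2cccnc2)sc1-c1nnc(-c2ccc(Cl)cc2)o1`. In this assay compound 3 gives > 100 ug/mL, also a limit of the assay.

Compound 3 therefore stands at the same limit as the other two compounds, and none of the three has a number of its own. The three shared a core, and the three steps among them, a step that the two limits leave unreadable from compound 1 to compound 2, a step that the two limits leave unreadable from compound 1 to compound 3 and a step that the two limits leave unreadable from compound 2 to compound 3, cannot be sized, since both ends of each step sit at the limit. Whatever the three changes did to cell tolerance is hidden above (the limit of > 100 ug/mL in this assay, at which 3 of the 3 values shown sit).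

Compound 4, `Cc1ccccc1-c1nnc(-c2sc(-c3cccnc3)nc2C)o1`, is the next member. It differs from compound 3 in one place: 2-methylphenyl in place of 4-chlorophenyl on an aromatic carbon. For the measured compounds named here, no measured step speaks for or against this change; the only guidance is that every compound of the core so far has sat at the limit.

Going by the values given here, compound 4 is therefore expected to remain at that limit, with a step that the limit leaves unreadable from compound 3 to compound 4 meaning no step that a reading could show. The estimate for compound 4 is 150 ug/mL, within 80 ug/mL and 300 ug/mL.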

Compound 4, half-maximal cytotoxic concentration: > 100 ug/mL
Compound 4 gave a limit, no number; the forecaster's own chance of this, stated with the estimate: 85%; the middle value does not contradict the limit.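

For the compounds shown here, compound 4 sits at a limit of the assay and not at a number, as do compound 1, compound 2 and compound 3, so no step from compound 4 to any of them can be read: the limit of > 100 ug/mL in this assay, at which 4 of the 4 values shown sit. The compounds shown leave open how far these four differ in tolerance in this assay, and which change to the shared core, if any, would give a measurable value.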